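The source may report more compounds than this note shows. Statements on the series, on what has been measured and on what is new or still open speak of the compounds shown alone.

Measured compounds:
- compound 1, `Cc1ccc(-c2nnc(-n3[se]c4ccccc4c3=O)s2)cc1`: 16600 nM
- compound 2, `O=c1c2ccccc2[se]n1-c1nnc(-c2cccc([N+](=O)[O-])c2)s1`: 27300 nM
- compound 3, `O=c1c2ccccc2[se]n1-c1nnc(-c2ccc(F)cc2)s1`: 42900 nM

All three were tested in a functional assay on SSMC-7721 cells (Homo sapiens) for antiproliferative activity, read by CCK-8 assay, with a stated time of 48 h; a higher number here means a weaker inhibitor, a lower number a stronger inhibitor. Compound 3 shows the highest number of the three. Its nearest neighbour is compound 2, a difference that lies within the scatter of repeated measurements, so the two cannot be told apart. Its furthest neighbour is compound 1, and the step of a 2.6-fold higher number from compound 1 to compound 3 (0.41 log units; beyond the scatter) is beyond the scatter, so compound 3 is the weaker of that pair.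

The next compound, compound 4, has the structure `Cc1cccc(-c2nnc(-n3[se]c4ccccc4c3=O)s2)c1`. It differs from compound 3 in one place: 3-methylphenyl in place of 4-fluorophenyl on an aromatic carbon. Within the data shown here, the only measured step that touches the same place is the one from compound 1 to compound 3, where fluoro in place of methyl raised the number by a 2.6-fold higher number from compound 1 to compound 3 (0.41 log units; beyond the scatter). Compound 4 reverses that exchange, bringing methyl back, though the methyl now stands on a different carbon of the phenyl ring than in compound 1. Nothing measured here shows what that shift of position does on its own.

On that basis compound 4 is expected to move back toward compound 1, a step of roughly a 2.4-fold lower number from compound 3 to compound 4 (0.38 log units; beyond the scatter) in this assay. The estimate for compound 4 is therefore 18000 nM, with a range from 8000 nM to 40000 nM.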

Compound 4, half-maximal inhibitory concentration: 17800 nM
Estimate against measurement, compound 4: 1.0-fold (0.00 log units) above; the range from low to high includes it.
By their numbers in this assay, from the lowest: compounds 1, 4, 2 and 3 (each within the scatter of the next, the first and the last beyond it).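

In this assay, changing 4-methylphenyl to 3-methylphenyl gives a 1.1-fold higher number from compound 1 to compound 4 (0.03 log units; within the scatter) and cannot be told apart from no change, so moving the methyl between these two places on the phenyl ring has no readable effect. The exchange of 4-fluorophenyl for 3-methylphenyl gives a 2.4-fold lower number from compound 3 to compound 4 (0.38 log units; beyond the scatter) and lies beyond the scatter, so the gap first seen between a methyl compound and the fluoro compound also appears with the methyl in its new place, although this step changes both the group and its place on the ring. Replacing nitro with methyl gives a 1.5-fold lower number from compound 2 to compound 4 (0.19 log units; within the scatter) and lies within the scatter, so these two groups cannot be separated here, and the series does not divide simply into methyl compounds on one side and all other groups on the other.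

It remains open whether a methoxy group, an amine, a carboxylic acid or a longer chain such as propyl on the phenyl ring would fall among these compounds or move clearly away from them. Nothing available here explains the differences seen among these compounds.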